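Replacing Fluoro with Trifluoromethyl on the Sulfonyl Ring

The source may report more compounds than this note shows. Statements on the series, on what has been measured and on what is new or still open speak of the compounds shown alone.

Compound 1: `CN1CCN(c2ccc(C3=NNC(c4ccc(N(C)C)cc4)C3)cc2)CC1`, 31.2%
Compound 2: `Cc1ccc(S(=O)(=O)N2N=C(c3ccc(N4CCN(C)CC4)cc3)CC2c2ccc(N(C)C)cc2)cc1`, 32.2%
Compound 3: `CN1CCN(c2ccc(C3=NN(S(=O)(=O)c4ccc(F)cc4)C(c4ccc(N(C)C)cc4)C3)cc2)CC1`, 92.3%

Of the compounds shown here, three have been measured in a functional assay on HCC1806 cells (Homo sapiens) for inhibition, read by sulforhodamine B assay, tested at 10 uM; on this read-out higher numbers stand for more inhibition at the one concentration tested (going by the name of the read-out) and lower numbers for less inhibition. Compound 3 stands highest of the three; its nearest neighbour is compound 2, and the gaps from compound 3 to compound 2 and to compound 1 are both beyond the scatter. The steps from the unsubstituted compound 1 show this: a number 1 percentage points higher from compound 1 to compound 2 (within the scatter), whereas a number 61.1 percentage points higher from compound 1 to compound 3 (beyond the scatter).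

Compound 4, `CN1CCN(c2ccc(C3=NN(S(=O)(=O)c4ccc(C(F)(F)F)cc4)C(c4ccc(N(C)C)cc4)C3)cc2)CC1`, is not yet measured. It differs from compound 3 in one place: trifluoromethyl in place of fluoro on an aromatic carbon.

The step that bears most directly on this change is the one at the same aromatic carbon, a number 60.1 percentage points higher from compound 2 to compound 3 (beyond the scatter). Within the data shown here, that step shows that what sits on this carbon matters greatly in this assay, but no measured pair tells how trifluoromethyl compares with fluoro there. Methyl gave a low number and fluoro a high one; trifluoromethyl could fall anywhere between. The account therefore expects compound 4 to lose some of the inhibition of compound 3, with a wide range: a number 22.3 percentage points lower from compound 3 to compound 4 (beyond the scatter) is the estimated step. For compound 4 the expected value is 70%, between 30% and 95%.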

Compound 4, a percentage reported as inhibition, at one concentration (the size of the read-out at that concentration, not a potency): 27%
Estimate against measurement, compound 4: 43 percentage points above; measured number outside the range, below it.
By their numbers in this assay, from the lowest: compounds 4, 1 and 2 (each within the scatter of the next); then compound 3.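

In this assay, the high number at this aromatic carbon belongs to fluoro alone: trifluoromethyl in place of fluoro gives a number 65.3 percentage points lower from compound 3 to compound 4 (beyond the scatter) and so removes nearly all of the gain seen with fluoro, while trifluoromethyl in place of methyl gives a number 5.2 percentage points lower from compound 2 to compound 4 (within the scatter) and so leaves the two groups indistinguishable in this read-out. Trifluoromethyl therefore does not fall between methyl and fluoro but sits level with methyl, and among the three sulfonyl compounds only compound 3 stands apart, so the larger group that also carries fluorine does not share what fluoro brings here. No measurement of any property of these compounds is available to account for this difference.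

The compounds shown leave open whether the high number is particular to fluoro or is shared by other small groups on this carbon, such as chloro, a hydroxyl, methoxy, a nitrile or an amine. They also leave open how compound 3 and compound 4 would compare across a range of concentrations, since each has a number at a single concentration and neither has a measure of potency.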